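The source may hold more compounds than are shown below. What is called first, only, known or untested is meant among the compounds shown, and "the series" means these compounds.

Measured so far in an assay on CHO cells for displacement of a labelled ligand from adenosine receptor A3 (Homo sapiens), read by scintillation counting, with a stated time of 120 min, tested at 10 uM; on this read-out higher numbers stand for more inhibition at the one concentration tested (going by the name of the read-out) and lower numbers for less inhibition:
Compound 1, `Nc1scc(CN2CCN(c3ccc(Cl)cc3F)CC2)c1C(=O)c1ccc(Cl)cc1`: compound 1 gives 1%.
Compound 2, `Nc1scc(CN2CCN(c3ccccc3F)CC2)c1C(=O)c1ccc(Cl)cc1`: compound 2 gives 0%.
Compound 3, `Nc1scc(CN2CCN(c3ccccc3Cl)CC2)c1C(=O)c1ccc(Cl)cc1`: compound 3 gives 0%.

All three compounds share one core and differ only in the substitution of the ring on the amine nitrogen. From compound 2 to compound 3 the change is chloro in place of fluoro on an aromatic carbon, and the step in this assay is no change at the digits printed from compound 2 to compound 3 (within the scatter). From compound 2 to compound 1 the change is chloro in place of hydrogen on an aromatic carbon, with a step of a number 1 percentage points higher from compound 2 to compound 1 (within the scatter). Between compound 1 and compound 3 the step is a number 1 percentage points lower from compound 1 to compound 3 (within the scatter). None of these three numbers can be told apart from the others.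

Compound 4, `Nc1scc(CN2CCN(c3c(Cl)cccc3Cl)CC2)c1C(=O)c1ccc(Cl)cc1`, has not yet been measured. It differs from compound 3 by chloro in place of hydrogen on an aromatic carbon. This is the same kind of change as that from compound 2 to compound 1, but not the same: there the entering chloro sits meta to a fluoro group and para to a large group, here it sits ortho to a large group and meta to a chloro group. From compound 3 to compound 4 a step of a number 1 percentage points higher from compound 3 to compound 4 (within the scatter) in this assay is expected, because the earlier step of the same kind, a number 1 percentage points higher from compound 2 to compound 1 (within the scatter), lay within the scatter and compound 3 stands at 0%. Compound 4 is thus estimated at 1%, expected to fall between -6% and 9%.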

Compound 4, a percentage reported as inhibition, at one concentration (the size of the read-out at that concentration, not a potency): 1%
Estimate against measurement, compound 4: no gap at the digits printed; low and high end bracket the measured number.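

In this assay, chloro in place of hydrogen on an aromatic carbon gave a number 1 percentage points higher from compound 3 to compound 4 (within the scatter), and set beside the earlier case of this change, the result reads: the same change on two cores in this assay, a number 1 percentage points higher (within the scatter) from compound 2 to compound 1 and a number 1 percentage points higher (within the scatter) from compound 3 to compound 4, 0 percentage points apart, within the scatter of two such steps
The two other new comparisons, a number 1 percentage points higher from compound 2 to compound 4 (within the scatter) and no change at the digits printed from compound 1 to compound 4 (within the scatter), likewise separate nothing. Among the compounds shown here, the agreement shows only that this change left no readable mark on the number in either setting; it does not show that the change carries a real effect from one core to the other, and it says nothing about how the change would behave in a compound whose inhibition stood clear of the scatter.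

The compounds shown carry only chloro and fluoro on the aromatic ring on the amine nitrogen, so the outcome with a methoxy group, an amine or a carboxylic acid there stays open. Also open, from the compounds shown here alone, is whether any change to the shared core would give a reading in this assay that can be told apart from these.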